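The source may report more compounds than this note shows. Statements on the series, on what has been measured and on what is new or still open speak of the compounds shown alone.

Measured so far in a functional assay on BGC-823 cells (Homo sapiens) for cytotoxicity, read by CCK-8 assay, with a stated time of 72 h; a lower number here means a stronger inhibitor, a higher number a weaker inhibitor:
Compound 1 `C=CCn1c(=O)/c(=C\c2ccccc2Cl)[nH]c(=O)/c1=C\c1ccccc1OC` gives 4600 nM.
Compound 2 `C=CCn1c(=O)/c(=C\c2cc(Br)ccc2F)[nH]c(=O)/c1=C\c1ccccc1OC` is reported as "not active" (no number reported), without a number.
Compound 3 `C=CCn1c(=O)/c(=C\c2ccccc2OC)[nH]c(=O)/c1=C\c1ccccc1OC` gives 13400 nM.

Compound 3 therefore stands with the highest of the two numbers reported, that is, as the weaker inhibitor of the two; its nearest neighbour is compound 1, and the step of a 2.9-fold higher number from compound 1 to compound 3 (0.46 log units; beyond the scatter) separates them, a modest gap that lies beyond the scatter.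

Compound 4 `C=CCn1c(=O)/c(=C\c2ccc(C)cc2)[nH]c(=O)/c1=C\c1ccccc1OC` differs from compound 3 by 4-methylphenyl in place of 2-methoxyphenyl on a double-bonded chain carbon bound to an aromatic carbon. Among the compounds with values here, no measured step exchanges the substituent on that ring in exactly this way, so the expectation rests on one comparison only: the step of a 2.9-fold higher number from compound 1 to compound 3 (0.46 log units; beyond the scatter) shows that changing the group on this ring shifts the number modestly, while compound 2, which carries two halogens on the same ring, was not active. A shift of similar size, in either direction, is expected for compound 4, with a real chance that it comes out within the scatter. The estimated step is a 1.2-fold lower number from compound 3 to compound 4 (0.09 log units; within the scatter), and compound 4 is expected at about 11000 nM, within a range from 3000 nM to 40000 nM.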

Compound 4, half-maximal inhibitory concentration: "not active" (no number reported)
Compound 4: no number reported; no gap can be computed for the estimate.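

In this assay, within the data shown here, compound 4 is reported as not active, without a number, and no step from compound 3 can be read. No measured information here accounts for this result. The compounds shown leave open how much weaker compound 4 is than compound 3, if at all.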